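Fluoro for methylsulfanyl on the shared core

The source may hold more compounds than are shown below. What is called first, only, known or untested is meant among the compounds shown, and "the series" means these compounds.

Measured compounds:
compound 1, `CSC1(C)C(=O)N(c2ccccc2)c2ncccc21`, 34%
compound 2, `CC1(C)C(=O)N(c2ccc(Cl)c(Cl)c2)c2ncccc21`, 26%

Of the compounds shown here, two have been tested in a functional assay on the whole organism (Pleural cavity) for inhibition, with Rattus norvegicus as the target, at a dose of 25 mg/kg; a lower number here means less inhibition, a higher number more inhibition at the dose given (going by the name of the read-out). Compound 1 gives 34%. Compound 2 carries two chlorines on its phenyl ring and a plain methyl where compound 1 has a methylsulfanyl group. Compound 2 gives 26%. The two numbers differ by an amount that lies within the usual scatter of this kind of measurement, so compound 1 and compound 2 cannot be told apart on the evidence at hand, and nothing in these two results is a single clean change that can guide a prediction.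

Compound 3, `CC1(F)C(=O)N(c2ccccc2)c2ncccc21`, differs from compound 1 in one place: fluoro in place of methylsulfanyl on a saturated ring carbon. For the measured compounds named here, no measured pair shows what this kind of change does here, so the step is estimated rather than derived. The change leaves the core and the phenyl ring untouched and is small in atom count, so the step is expected to be of no size beyond the scatter, with perhaps a slight downward lean; the expected step is a number 4 percentage points lower from compound 1 to compound 3 (within the scatter). Compound 3 is therefore estimated to give 30% in this assay, with a likely range from 15% to 45%.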

Compound 3, a percentage reported as inhibition, in the whole organism at one dose (the size of the read-out at that dose, not a potency): 50%
Beside the measured number, compound 3's estimate is 20 percentage points below it; the whole stated range lies below it.
By their numbers in this assay, from the lowest: compounds 2 and 1 (each within the scatter of the next); then compound 3.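

In this assay, for the compounds shown here, fluoro in place of methylsulfanyl on a saturated ring carbon gives a number 16 percentage points higher from compound 1 to compound 3 (beyond the scatter) and is the first single change in this set whose effect can be read. The core and the phenyl ring stay the same in this pair, so the difference in the read-out goes with this one position, two ring bonds from the ring nitrogen, and shows that the group carried there can shift the inhibition seen at this dose. Nothing at hand explains why this swap moves the number in this direction.

A single pair cannot separate a gain from having fluoro at this position from a gain from losing methylsulfanyl, and it gives no trend across groups. From the compounds shown here alone, it also remains open where a hydroxyl group, an amine or a longer chain such as ethyl on the same ring carbon would fall, and whether the swap to fluoro would act the same way on a phenyl ring that carries two chlorines.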